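A few compounds are considered here, and "the series" means these few. Any claim that something is new, unique, unknown or untested is made for them only; others in the source may bear on it.

In a functional assay on HEK293 cells with D(4) dopamine receptor (Homo sapiens) as the target, read by FLIPR (on this read-out lower numbers stand for smaller maximal responses and higher numbers for larger maximal responses), three compounds have been measured so far. Compound 1 `O/N=C(\CCN1CCN(c2ncccn2)CC1)c1ccccc1` gives 49%. Compound 2 `CO/N=C(\CCN1CCN(c2ccccn2)CC1)c1ccc(Cl)cc1` gives 87%, and compound 3 `CO/N=C(/CCN1CCN(c2ccccn2)CC1)c1ccc(Cl)cc1` gives 68%. Compound 3 thus stands second highest of the three, with compound 1 lower and compound 2 higher, each of these gaps beyond the scatter. For the measured compounds named here, the only single-point step among the measured compounds, a number 19 percentage points lower from compound 2 to compound 3 (beyond the scatter), rests on (the fact that compounds 2 and 3 differ only in the configuration as drawn). Compound 4 `CO/N=C(/CCN1CCN(c2ccccn2)CC1)c1ccc(Cl)c(Cl)c1` differs from compound 3 by chloro in place of hydrogen on an aromatic carbon. Going by the values given here, none of the measured steps concerns a chloro group entering or leaving an aromatic ring, so the step from compound 2 to compound 3 does not speak to this change. Among the compounds with values here, with no measured step pointing in either direction, the change is expected to yield a step that stays within the usual scatter. Compound 4 is therefore estimated at 68%, with a range from 45% to 88%, which means an expected step of no change at the digits printed from compound 3 to compound 4 (within the scatter).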

Compound 4, largest response reached (reported as efficacy), in percent of the reference or control that the assay uses: 63%
Compound 4: middle estimate off by 5 percentage points, on the high side; measured number inside the range.
By their numbers in this assay, from the lowest: compound 1; then compounds 4 and 3 (each within the scatter of the next); then compound 2.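

For the compounds shown here, the change from 4-chlorophenyl to 3,4-dichlorophenyl comes out as a number 5 percentage points lower from compound 3 to compound 4 (within the scatter) in this assay and is the first measured step that concerns a group on the aromatic ring. It shows that a second chloro group on this aromatic carbon, ortho to a chloro group and meta to a large group, does not move the maximal response beyond the scatter, at least with the double bond drawn Z as in compound 3. Nothing known about these compounds accounts for this step.

The compounds shown leave open whether the same chloro group would give a similar step with the double bond drawn E, as in compound 2. They also leave open what fluoro, methyl, methoxy or trifluoromethyl would give at this same place on the ring.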